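A few compounds are considered here, and "the series" means these few. Any claim that something is new, unique, unknown or untested is made for them only; others in the source may bear on it.

Measured in an ADME assay on WI-38 cells (Homo sapiens) for cytotoxicity, read by MTT assay, with a stated time of 72 h; a higher number here means a weaker inhibitor, a lower number a stronger inhibitor:

- Compound 1 `O=C(CCc1cccc2c1B(O)OC2)NCc1ccccc1`: > 100000 nM (a limit of the assay)
- Compound 2 `O=C(CCc1cccc2c1B(O)OC2)Nc1nccs1`: > 100000 nM (a limit of the assay)
- Compound 3 `O=C(CCc1cccc2c1B(O)OC2)Nc1ccc(Br)cc1`: 42000 nM

Of these three, only compound 3 gives an actual number, 42000 nM, so it cannot be ranked on a scale of measured values. Compound 4 `CCOC(=O)c1ccc(NC(=O)CCc2cccc3c2B(O)OC3)cc1` keeps the shared core and the amide of compound 3 and differs on the aromatic ring: ethoxycarbonyl in place of bromo on an aromatic carbon. For the measured compounds named here, two measured steps bear on this change, though only indirectly, as both alter the group on the amide-type nitrogen: an at least 2.3-fold lower number from compound 1 to compound 3 (0.37 log units; beyond the scatter), and an at least 2.3-fold lower number from compound 2 to compound 3 (0.37 log units; beyond the scatter). Neither step replaces the bromo group, and the other end of each is the limit of > 100000 nM in this assay, at which 2 of the 3 values shown sit. The size of the coming step in this assay is therefore poorly fixed, but a modest rise in the number, toward that limit, is expected. The expected change is a 1.4-fold higher number from compound 3 to compound 4 (0.15 log units; within the scatter). For compound 4 the estimated value is 60000 nM. The expected range for compound 4 runs from 22000 nM to 100000 nM.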

Compound 4, half-maximal inhibitory concentration: > 100000 nM
Compound 4: only a limit was reported; the forecaster's own chance of this, stated with the estimate: 35%; middle value at least 1.6-fold (0.22 log units) from the limit.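

The earlier compounds shown here changed only the group on the amide-type nitrogen, whereas in this assay this pair keeps that nitrogen and its aromatic ring and changes only the group on the ring, giving an at least 2.3-fold higher number from compound 3 to compound 4 (0.37 log units; beyond the scatter) with ethoxycarbonyl in place of bromo. The measurable number of compound 3 therefore depends on what sits on this aromatic carbon, not only on an aromatic ring being attached to the amide-type nitrogen. Compound 4 gives > 100000 nM as a limit of the assay, so the step has no upper end, and the set now stands as follows: the limit of > 100000 nM in this assay, at which 3 of the 4 values shown sit.

Going by these compounds, whether a chloro group, an amine or a carboxylic acid on this aromatic carbon would give a number or stay at the limit remains open. So does the effect of a longer chain between the shared core and the amide.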